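The source may hold more compounds than are shown below. What is called first, only, known or untested is meant among the compounds shown, and "the series" means these compounds.

In a functional assay on the whole organism (Tail, strain ICR) with Mus musculus as the target, in the tail flick test, with a stated time of 150 min, at a dose of 25 umol/kg by the oral route (on this read-out lower numbers stand for a weaker effect and higher numbers for a stronger effect at the one dose given), three compounds of one shared core have been measured. Compound 1, `O=C(O)[C@@H]1CCCN1C(=O)CN(c1nc(Cl)nc2[nH]cnc12)C1CC1`, gives 7.29%. Compound 2, `O=C(CN(c1ncnc2c1ncn2C1CCCCO1)C1CC1)N[C@@H](CO)C(=O)OCc1ccccc1`, gives 18.3%. Compound 3, `NCCCC[C@H](NC(=O)CN(c1nc(Cl)nc2[nH]cnc12)C1CC1)C(=O)OCc1ccccc1`, gives 9.88%. All three numbers lie close together: the number of compound 1 is within the usual scatter of that of compound 3, and so is the number of compound 2, which is the furthest of the three from compound 3. On the numbers shown, compound 3 therefore cannot be told apart from either of its companions.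

Compound 4, `O=C(CN(c1nc(Cl)nc2[nH]cnc12)C1CC1)N[C@@H](CCC(=O)OCc1ccccc1)C(=O)OCc1ccccc1`, has not been measured in this assay. It differs from compound 3 in one place: benzyloxycarbonyl in place of 2-aminoethyl on a saturated chain carbon, three bonds along the chain from an amide-type nitrogen and a carbonyl carbon. Going by the values given here, no pair of measured compounds shows this or any other single change, so nothing in the data says how such a change moves this assay. The three measured compounds, which differ among themselves in several places at once, all give low numbers within the scatter of one another.

On that basis compound 4 is expected to give a similarly low number, and the step from compound 3 to compound 4 is estimated as a number 1.1 percentage points higher from compound 3 to compound 4 (within the scatter), which would stay within the usual scatter. Compound 4 is estimated at 11%, with a range from 3% to 25%.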

Compound 4, a percentage reported as activity, at one dose (the size of the read-out at that dose, not a potency): 44.5%
Compound 4: the middle estimate sits 33.5 percentage points below what was measured; the whole stated range lies below it.
By their numbers in this assay, from the lowest: compounds 1, 3 and 2 (each within the scatter of the next, the first and the last beyond it); then compound 4.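

In this assay, going by these compounds alone, the exchange of 2-aminoethyl for benzyloxycarbonyl, on a saturated chain carbon, three bonds along the chain from an amide-type nitrogen and a carbonyl carbon, gives a number 34.6 percentage points higher from compound 3 to compound 4 (beyond the scatter) and so provides the first single-place comparison in this set, showing that the read-out responds to what is carried at this position. The same difference, read one bond further out as 4-aminobutyl to 2-(benzyloxycarbonyl)ethyl, removes a chain-end amine and brings in an ester and a six-membered aromatic ring together, so this one step cannot assign the gain to any single part of the change. Nothing available explains why the read-out moves with this exchange.

The compounds shown leave open whether the ester, the aromatic ring or the loss of the amine accounts for the step, and a chain ending in a carboxylic acid, a methyl ester or a plain phenyl group would begin to separate these. They also leave open whether a shorter or longer chain between this carbon and the benzyl ester would keep the effect.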